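A few compounds are considered here, and "the series" means these few. Any claim that something is new, unique, unknown or untested is made for them only; others in the source may bear on it.

Compound 1 `Cn1nc2c(=O)n(CC3(O)CCN(Cc4ccc(-c5ccco5)cc4Cl)CC3)cnc2c1-c1ccc(CNCCO)cc1` and compound 2 `CC(=O)NCc1ccc(-c2c3ncn(CC4(O)CCN(Cc5ccc(-c6ccco6)cc5Cl)CC4)c(=O)c3nn2C)cc1` share one core and differ only in the group carried on the benzylic amine. In an assay on isolated protein for inhibition of ubiquitin carboxyl-terminal hydrolase 7 (Homo sapiens), with stated times of 30 min and 2 h (a higher number here means a weaker inhibitor, a lower number a stronger inhibitor), compound 1 gives 8.2 nM, while compound 2 gives 46.1 nM. Compound 2 thus stands with the highest, that is weakest, number of the two, the step of a 5.6-fold higher number from compound 1 to compound 2 (0.75 log units; beyond the scatter) lying beyond the scatter. Compound 3 `Cn1nc2c(=O)n(CC3(O)CCN(Cc4ccc(-c5ccco5)cc4Cl)CC3)cnc2c1-c1ccc(CO)cc1` is the next compound, and its difference from compound 2 is hydroxy in place of acetamido on a saturated chain carbon bound to an aromatic carbon. Among the compounds with values here, the only measured step that bears on this position is the one from compound 1 to compound 2, where a small polar group on the side chain gave the lower number and the acetamide the higher one. A similarly small polar hydroxy group is therefore expected to bring the number down again, so the step of a 2.3-fold lower number from compound 2 to compound 3 (0.36 log units; beyond the scatter) is expected to be modest and toward stronger inhibition. Compound 3 is accordingly estimated at 20 nM, within a range from 7 nM to 60 nM.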

Compound 3, half-maximal inhibitory concentration: 42.5 nM
For compound 3 the middle estimate is 2.1-fold (0.33 log units) below the measured one; measured number inside the range.
By their numbers in this assay, from the lowest: compound 1; then compounds 3 and 2 (each within the scatter of the next).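

In this assay, hydroxy in place of acetamido gives a 1.1-fold lower number from compound 2 to compound 3 (0.04 log units; within the scatter) and so does not separate these two groups at this position. Hydroxy in place of (2-hydroxyethyl)amino gives a 5.2-fold higher number from compound 1 to compound 3 (0.71 log units; beyond the scatter) and thus shows that a hydroxy group on this chain carbon does not by itself match compound 1, which alone among the three stands apart from the others. Nothing measured here explains this difference.

The compounds shown leave open whether compound 1 owes its number to the amine nitrogen, the terminal hydroxy or both together. A simple aminomethyl group, a 2-hydroxyethoxymethyl chain with oxygen in place of that nitrogen, or a longer amino alcohol chain at this position would help separate these possibilities.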